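Changing the aryl group on the hydrazone of a rat inhibition series

A few compounds are considered here, and "the series" means these few. Any claim that something is new, unique, unknown or untested is made for them only; others in the source may bear on it.

Measured compounds:
Compound 1, `CC1CC/C(=N\Nc2cccc(Br)c2)c2ncc(C(=O)O)c(=O)n21`: > 320 umol/kg
Compound 2, `CCOc1cccc(N/N=C2\CCC(C)n3c2ncc(C(=O)O)c3=O)c1`: > 1000 umol/kg
Compound 3, `CC(=O)c1cccc(N/N=C2\CCC(C)n3c2ncc(C(=O)O)c3=O)c1`: > 1000 umol/kg

In a functional assay on the whole organism for inhibition, with Rattus norvegicus as the target (a lower number here means that less compound is needed, a higher number that more compound is needed for the effect), compound 1 gives > 320 umol/kg, which is a limit of the assay and not a number. Compound 2 gives > 1000 umol/kg, also a limit. Compound 3 likewise gives > 1000 umol/kg, again a limit. Among the measured compounds shown here, no compound in this set has a measured value; where compound 1 stands can only be stated as a limit, and the two other values shown are limits too, as summarised in the limit of > 1000 umol/kg in this assay, at which 2 of the 3 values shown sit, and (the limit of > 320 umol/kg in this assay, at which 1 of the 3 values shown sits).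

Compound 4, `CCc1ccc(N/N=C2\CCC(C)n3c2ncc(C(=O)O)c3=O)cc1`, is not yet measured. It differs from compound 1 in one place: 4-ethylphenyl in place of 3-bromophenyl on an amine nitrogen. The measured steps that come closest are changes of the group on the aromatic ring, namely a step that the two limits leave unreadable from compound 1 to compound 2, a step that the two limits leave unreadable from compound 1 to compound 3 and a step that the two limits leave unreadable from compound 2 to compound 3, and each of these is unreadable because both ends are limits. For the measured compounds named here, no measured step therefore gives a size or a direction for the change to compound 4.

The expectation is that compound 4 will again reach only a limit, with the step that the limit leaves unreadable from compound 1 to compound 4 estimated as no change beyond the scatter. Compound 4 is therefore estimated at 1000 umol/kg, in the range from 300 umol/kg to 3000 umol/kg.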

Compound 4, dose for 50% inhibition: > 1000 umol/kg
Compound 4 was reported as a limit; the forecaster's own chance of this, stated with the estimate: 80%; the middle value lies on the limit itself.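

In this assay compound 4 gives > 1000 umol/kg, a limit of the assay and not a number. Compound 1 is also only a limit, so the step from compound 1 to compound 4 cannot be read. The compounds shown leave open whether changing the aryl group alters the dose needed at all.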